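Benzamide Trimming on a Pyrazole Urea-Amide Series

The compounds below may be only part of what the source reports. "The series", "measured", "known", "first", "only" and "open" are said of these compounds alone.

Compound 1 `O=C(Nc1cccc(-n2cc(-c3ccncc3)c(-c3ccc(Cl)c(O)c3)n2)c1)Nc1ccc(Cl)c(Cl)c1`: 1030 nM
Compound 2 `COc1cc(-c2nn(-c3cccc(NC(=O)c4ccc(Cl)c(C(F)(F)F)c4)c3)cc2-c2ccncc2)ccc1Cl`: 1620 nM

In a functional assay on RPMI-8226 cells (Homo sapiens) for inhibition, read by sulforhodamine B assay, with a stated time of 48 h (on this read-out higher numbers stand for weaker inhibition and lower numbers for stronger inhibition), compound 2 gives 1620 nM, and compound 1 gives 1030 nM; the two numbers sit within the usual scatter of each other, so neither can be set apart from the other. Compound 3 `COc1cc(-c2nn(-c3cccc(NC(=O)c4ccccc4)c3)cc2-c2ccncc2)ccc1Cl` has not yet been measured. It differs from compound 2 in one place: phenyl in place of 4-chloro-3-(trifluoromethyl)phenyl on a carbonyl carbon. Among the measured compounds shown here, no measured pair shows this kind of change, so the size of the step is uncertain. The step of a 2.5-fold higher number from compound 2 to compound 3 (0.39 log units; beyond the scatter) is expected to run toward weaker inhibition, beyond the scatter. Compound 3 is therefore estimated at 4000 nM, with a range from 1500 nM to 12000 nM.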

Compound 3, half-maximal inhibitory concentration: 850 nM
Beside the measured number, compound 3's estimate is 4.7-fold (0.67 log units) above it; measured number outside the range, below it.
By their numbers in this assay, from the lowest: compounds 3, 1 and 2 (each within the scatter of the next).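

In this assay, among the compounds shown here, the step of a 1.9-fold lower number from compound 2 to compound 3 (0.28 log units; within the scatter) is the first measured change at this position, and it stays within the scatter. On this carbonyl carbon, the plain phenyl of compound 3 therefore cannot be told apart from the 4-chloro-3-(trifluoromethyl)phenyl of compound 2. Nothing available gives a reason for this outcome. As far as these compounds go, what a carbonyl carbon bearing no aromatic ring would give, such as one carrying cyclohexyl or a longer alkyl chain, remains open. So does the effect of a carboxylic acid or an amine on the phenyl.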